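This account rests on a few compounds, and the source may have more. Where it says the series, first, only, none or still open, it means among the compounds named here.

Working notes on the series, followed in a functional assay on MCF7 cells (Homo sapiens) for antiproliferative activity, read by sulforhodamine B assay, with a stated time of 48 h; a higher number here means a weaker inhibitor, a lower number a stronger inhibitor. Compound 1 (`Cc1ccc(OS(=O)(=O)c2ccc(N3CCN(C)C3=O)cc2)cc1`) gives > 100000 nM, which is a limit and not a number. Compound 2 (`CN1CCN(c2ccc(S(=O)(=O)Oc3ccc(F)cc3)cc2)C1=O`) gives > 100000 nM, which is also a limit and not a number. For the measured compounds named here, compound 2 therefore has no readable potency, and the only other value offers no numerical comparison: the limit of > 100000 nM in this assay, at which 2 of the 2 values shown sit.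

The next compound is compound 3 (`CN1CCN(c2ccc(S(=O)(=O)Oc3ccc(Cl)cc3)cc2)C1=O`). The change from compound 2 is chloro in place of fluoro on an aromatic carbon, para to a large group.

Going by the values given here, one measured step bears on this change, a swap of a single substituent on the same aromatic ring: a step that the two limits leave unreadable from compound 1 to compound 2. It gives no size to carry forward, so the data support no direction for the new swap. With nothing pointing to a gain, no step beyond the scatter is expected in this assay, and compound 3 will most likely also report only a limit. The estimated step is a number no higher from compound 2 to compound 3 (the limit leaves the size open). For compound 3 the estimated value is 100000 nM, with an expected range from 40000 nM to 200000 nM.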

Compound 3, half-maximal inhibitory concentration: > 100000 nM
Compound 3: a limit, no number (the forecaster's own chance of this, stated with the estimate: 85%); the middle value sits exactly at the limit.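

No new step can be read in this assay: compound 3 reports only a limit, so its comparisons with compound 1 and compound 2 stay unreadable, and the series rests on one limit: the limit of > 100000 nM in this assay, at which 3 of the 3 values shown sit.

Compound 1, compound 2 and compound 3 leave open whether methyl, fluoro and chloro on this aromatic carbon differ at all in potency.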